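Trimethoxyphenyl Pyrazolyl Chalcones: Removing One Methoxy Group

This account rests on a few compounds, and the source may have more. Where it says the series, first, only, none or still open, it means among the compounds named here.

Measured compounds:
Compound 1, `COc1cc(-c2cc(/C=C/C(=O)c3ccc(N)cc3)[nH]n2)cc(OC)c1OC`: 43%
Compound 2, `COc1ccc(-c2cc(/C=C/C(=O)c3ccc(N)cc3)[nH]n2)cc1OC`: 71%
Compound 3, `COc1cc(C(=O)/C=C/c2cc(-c3cc(OC)c(OC)c(OC)c3)n[nH]2)cc(OC)c1OC`: 94%

All three were tested in a functional assay on K562 cells (Homo sapiens) for cytotoxicity, read by sulforhodamine B assay, with a stated time of 48 h, tested at 1 uM; on this read-out higher numbers stand for a weaker effect at the one concentration tested and lower numbers for a stronger effect. Compound 1 gives 43%, compound 2 gives 71%, and compound 3 gives 94%. Compound 1 and compound 2 differ by a single change, (hydrogen in place of methoxy on an aromatic carbon), and this change shifts the read-out by a number 28 percentage points higher from compound 1 to compound 2 (beyond the scatter). Compound 3 carries the highest number of the three; its gap to compound 2 and its larger gap to compound 1 both exceed the usual scatter. How the core of compound 3 differs from the core of compound 1 is not broken down here.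

Compound 4, `COc1ccc(-c2cc(/C=C/C(=O)c3cc(OC)c(OC)c(OC)c3)[nH]n2)cc1OC`, is not yet measured. It arises from compound 3 by hydrogen in place of methoxy on an aromatic carbon, the same change that turns compound 1 into compound 2, at a place described in identical words in both cases. In compound 1 that change raised the number by a number 28 percentage points higher from compound 1 to compound 2 (beyond the scatter). The read-out for compound 3, however, already stands close to the top of the scale, so the room for a comparable rise is small. The step from compound 3 to compound 4 is therefore expected to be only a number 4 percentage points higher from compound 3 to compound 4 (within the scatter). Compound 4 is estimated at 98% in this assay. Compound 4 is expected to fall between 86% and 106%.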

Compound 4, a percentage reported as activity, at one concentration (the size of the read-out at that concentration, not a potency): 43%
Estimate against measurement, compound 4: 55 percentage points above, and the stated range ends above it.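

In this assay, putting hydrogen in place of methoxy on the core of compound 3 gives a large step, a number 51 percentage points lower from compound 3 to compound 4 (beyond the scatter), and on this read-out a lower number means a stronger effect. The same change on the core of compound 1 weakened the effect instead, so the two steps disagree in direction and not only in size, and the result of this change cannot simply be carried from one core to the other in this series: the same change on two cores in this assay, a number 28 percentage points higher (beyond the scatter) from compound 1 to compound 2 and a number 51 percentage points lower (beyond the scatter) from compound 3 to compound 4, 79 percentage points apart, beyond the scatter of two such steps. What this does not show is why the two cores answer in opposite ways: two pairs of compounds, each read at a single concentration, give one direction on each core, but neither a general rule nor a potency.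

The compounds shown leave open how a hydroxyl group or an ethoxy group in place of that methoxy would read in this assay, which would show whether only the loss of the methoxy group matters or whether other groups at that place matter too. They also leave open which of the two directions, if either, would appear on a third core, for example one carrying a carboxylic acid in place of the amine of compound 1.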